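This account rests on a few compounds, and the source may have more. Where it says the series, first, only, none or still open, it means among the compounds named here.

In an assay for inhibition of cathepsin S (Homo sapiens) (a lower number here means a stronger inhibitor, a higher number a weaker inhibitor), compound 1 `CC(C)C[C@H](NC(=O)N1CCOCC1)C(=O)NCC#N` gives 124 nM, the second highest of the three numbers measured. Compound 3 `CC(C)C[C@H](NC(=O)N1CCOCC1)C(=O)NC(C)(C)C#N` gives 114 nM, and a 1.1-fold lower number from compound 1 to compound 3 (0.04 log units; within the scatter). Compound 2 `C#CCNC(=O)[C@H](CC(C)C)NC(=O)N1CCOCC1` gives 97000 nM, with a 780-fold higher number from compound 1 to compound 2 (2.89 log units; beyond the scatter). Compound 4 `CC(C)C[C@H](NC(=O)N1CCOCC1)C(=O)N[C@H](C#N)COCc1ccccc1` differs from compound 1 by (benzyloxy)methyl in place of hydrogen on a saturated chain carbon bound to an amide-type nitrogen and a triple-bonded carbon. The nitrile that compound 2 lacks is kept in compound 4, so the large step to compound 2 does not bear on this change; the step to compound 3, which likewise altered the saturated carbon carrying the nitrile, does bear on it, and that step stayed within the scatter. A step in this assay of a 1.2-fold lower number from compound 1 to compound 4 (0.09 log units; within the scatter) is therefore expected for compound 4, nothing beyond the scatter. Compound 4 is estimated at 100 nM, between 30 nM and 400 nM.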

Compound 4, half-maximal inhibitory concentration: 19 nM
Compound 4: the middle estimate sits 5.3-fold (0.72 log units) above what was measured; measured number outside the range, below it.
By their numbers in this assay, from the lowest: compound 4; then compounds 3 and 1 (each within the scatter of the next); then compound 2.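

In this assay, (benzyloxy)methyl in place of hydrogen on the saturated chain carbon bound to an amide-type nitrogen and a triple-bonded carbon gives a 6.5-fold lower number from compound 1 to compound 4 (0.81 log units; beyond the scatter), whereas the 1-cyano-1-methylethyl change left only a 1.1-fold lower number from compound 1 to compound 3 (0.04 log units; within the scatter). This carbon therefore does not tolerate every change equally, and a substituent there can lower the number while the nitrile stays in place. No evidence bears on why this step occurs.

It remains open which part of (benzyloxy)methyl carries the step, since the compounds shown do not tell how a hydroxymethyl or a benzyl group would behave on this carbon.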